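The source may report more compounds than this note shows. Statements on the series, on what has been measured and on what is new or still open speak of the compounds shown alone.

Measured compounds:
compound 1 `COc1cc2nc(OCC3CCN(C(=O)OC(C)(C)C)CC3)nc(Nc3ccc(S(C)(=O)=O)cc3F)c2cc1OC`: 33.2%
compound 2 `COc1cc2nc(Nc3ccc(S(C)(=O)=O)cc3F)nc(OC3CCN(C(=O)OC(C)(C)C)CC3)c2cc1OC`: 19.7%
compound 3 `COc1cc2nc(OC3CCN(C(=O)OC(C)(C)C)CC3)nc(Nc3ccc(S(C)(=O)=O)cc3F)c2cc1OC`: 19.6%

In a functional assay on HEK293 cells for agonist activity at Glucose-dependent insulinotropic receptor (Homo sapiens), read by cAMP accumulation, with a stated time of 60 min (a higher number here means a larger maximal response, a lower number a smaller maximal response), compound 2 stands second highest of the three numbers. Compound 2 and compound 3 lie within the scatter of each other, so nothing separates them, whereas compound 1 sits higher than compound 2 by a gap beyond the scatter. Compound 4 `COc1cc2nc(Nc3ccc(S(C)(=O)=O)cc3)nc(OC3CCN(C(=O)OC(C)(C)C)CC3)c2cc1OC` differs from compound 2 in one place: hydrogen in place of fluoro on an aromatic carbon. Going by the values given here, no measured pair shows this change on its own, so the data give no guide to its size. The expected step from compound 2 to compound 4 in this assay is a number 0.3 percentage points higher from compound 2 to compound 4 (within the scatter), a change not expected to exceed the scatter. Compound 4 is therefore estimated at 20%, within a range from 8% to 36%.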

Compound 4, largest response reached (Emax), in percent of the reference or control that the assay uses: 20.6%
Estimate against measurement, compound 4: 0.6 percentage points below; the range from low to high includes it.
By their numbers in this assay, from the lowest: compounds 3, 2 and 4 (each within the scatter of the next); then compound 1.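

In this assay, going by these compounds alone, the exchange of fluoro for hydrogen on this aromatic carbon, turning 2-fluoro-4-(methylsulfonyl)phenyl into 4-(methylsulfonyl)phenyl, gives a number 0.9 percentage points higher from compound 2 to compound 4 (within the scatter) and so provides the first direct reading of this change. At this position and on this core, the fluoro group is therefore not needed to hold the maximal response at the level of compound 2. No supporting data bear on why this is so.

Going by these compounds, whether chloro, methoxy or an amine on the same carbon would move the response remains open. So does whether the same exchange would leave compound 1 and compound 3 equally unchanged.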